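The source may report more compounds than this note shows. Statements on the series, on what has been measured and on what is new or still open speak of the compounds shown alone.

Among the measured compounds shown here, in an ADME assay on HepG2 cells (Homo sapiens) for cytotoxicity, read by MTT assay, with a stated time of 24 h (on this read-out lower numbers stand for higher toxicity in this test and higher numbers for lower toxicity in this test), compound 2 `CC(C)=CCC1=C(OCc2cn(-c3ccc(Cl)cc3)nn2)C(=O)c2ccccc2C1=O` gives 1150000 nM, the highest of the two numbers measured so far, and compound 1 `CC(C)=CCC1=C(OCc2cn(C3CCNCC3)nn2)C(=O)c2ccccc2C1=O` gives 570000 nM. For the measured compounds named here, the one measured step, a 2.0-fold higher number from compound 1 to compound 2 (0.30 log units; within the scatter), changes the group on the aromatic nitrogen, not the phenyl ring. Compound 3 `CC(C)=CCC1=C(OCc2cn(-c3ccc([N+](=O)[O-])cc3)nn2)C(=O)c2ccccc2C1=O` differs from compound 2 by nitro in place of chloro on an aromatic carbon. Going by the values given here, no measured step touches this position, so the expected change is none beyond the scatter, giving a 1.2-fold lower number from compound 2 to compound 3 (0.06 log units; within the scatter) as the estimate. For compound 3 the expected value in this assay is 1000000 nM, within a range of 400000 nM to 2500000 nM.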

Compound 3, half-maximal cytotoxic concentration: 540000 nM
For compound 3 the middle estimate is 1.9-fold (0.27 log units) above the measured one; low and high end bracket the measured number.
By their numbers in this assay, from the lowest: compounds 3, 1 and 2 (each within the scatter of the next, the first and the last beyond it).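

Among the compounds shown here, with nitro in place of chloro on the aromatic carbon para to a large group, this assay shows a 2.1-fold lower number from compound 2 to compound 3 (0.33 log units; beyond the scatter) as the first measured change at this position, so a swap here can shift the number modestly. Set against the piperidin-4-yl compound, the 4-nitrophenyl group gives a 1.1-fold lower number from compound 1 to compound 3 (0.02 log units; within the scatter) and thus no readable difference. No supporting data explain the shift seen with nitro. From the compounds shown here alone, whether an amine or a methoxy group at this same place would give a number closer to that of chloro or of nitro stays open.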